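Replacing the Ether Chain With a Methylphenyl Ring

The compounds below may be only part of what the source reports. "The series", "measured", "known", "first", "only" and "open" are said of these compounds alone.

Measured so far, in an assay on isolated protein for agonist activity at Bile acid receptor (Homo sapiens), read by TR-FRET, with a stated time of 3 h, in the absence of a further agent; a higher number here means that more compound is needed for the effect, a lower number that less compound is needed:
Compound 1 `CCCCOc1cccc(C(=O)Nc2cccc(C(=O)O)c2)c1` gives 3150 nM.
Compound 2 `CC(C)CCOc1cccc(C(=O)Nc2cccc(C(=O)O)c2)c1` gives 2760 nM.
Compound 3 `O=C(O)c1cccc(NC(=O)c2cccc(OCC3CC3)c2)c1` gives 1260 nM.

Among these three, compound 3 gives the lowest number in this assay, and both steps to it lie beyond the scatter: a 2.5-fold lower number from compound 1 to compound 3 (0.40 log units; beyond the scatter) and a 2.2-fold lower number from compound 2 to compound 3 (0.34 log units; beyond the scatter). The step of a 1.1-fold lower number from compound 1 to compound 2 (0.06 log units; within the scatter) lies within the scatter. All three steps vary only the saturated chain on the ether oxygen.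

Compound 4 `Cc1ccccc1-c1cccc(C(=O)Nc2cccc(C(=O)O)c2)c1` differs from compound 3 as follows: 2-methylphenyl in place of cyclopropylmethoxy on an aromatic carbon. Going by the values given here, no measured step bears directly on this change, since the ether oxygen itself is removed and an aromatic ring enters in its place; the measured steps show only that changes of the chain on that oxygen shifted this assay by modest amounts. The expectation for compound 4 is therefore anchored on compound 3 with wide uncertainty, with a step of a 1.2-fold higher number from compound 3 to compound 4 (0.08 log units; within the scatter) expected. Compound 4 is estimated at 1500 nM in this assay, within a range from 400 nM to 6000 nM.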

Compound 4, half-maximal effective concentration: 68 nM
Compound 4: middle estimate off by 22-fold (1.34 log units), on the high side, and the stated range ends above it.
By their numbers in this assay, from the lowest: compound 4; then compound 3; then compounds 2 and 1 (each within the scatter of the next).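

Going by these compounds alone, at this position, on an aromatic carbon meta to a large group, the earlier compounds showed only modest shifts in this assay as the chain on the ether oxygen varied, whereas replacing the whole ether with 2-methylphenyl gives a far larger shift (a 19-fold lower number from compound 3 to compound 4 (1.27 log units; beyond the scatter)), and the same holds against the isopentyloxy chain (a 41-fold lower number from compound 2 to compound 4 (1.61 log units; beyond the scatter)) and the butoxy chain (a 46-fold lower number from compound 1 to compound 4 (1.67 log units; beyond the scatter)). Compound 4 thus shows that the ether oxygen is not needed for the lowest number in this set. Nothing available explains why this change has so large an effect.

The change removes the oxygen and the saturated chain and brings in the aromatic ring all at once, so the compounds shown cannot separate these contributions. They also leave open what the methyl contributes, which a plain phenyl ring or a chlorophenyl ring in the same place would address.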